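The source may report more compounds than this note shows. Statements on the series, on what has been measured and on what is new or still open speak of the compounds shown alone.

Values in a functional assay on HepG2 cells (Homo sapiens) for antiproliferative activity, read by MTT assay, with a stated time of 48 h; on this read-out lower numbers stand for stronger inhibition and higher numbers for weaker inhibition
- compound 1 `CC(=O)N1N=C(c2ccc3ccccc3c2)OC1c1ccccc1Cl` gives 4.32 ug/mL
- compound 2 `CC(=O)N1N=C(c2ccc3ccccc3c2)OC1c1ccccc1F` gives 3.36 ug/mL
- compound 3 `CC(=O)N1N=C(c2ccc3ccccc3c2)OC1c1ccc(F)cc1` gives 1.82 ug/mL

Compound 3 cannot be separated from compound 2 (a 1.8-fold lower number from compound 2 to compound 3 (0.27 log units; within the scatter)), but it does stand apart from compound 1 (a 2.4-fold lower number from compound 1 to compound 3 (0.38 log units; beyond the scatter)). The third measured step, a 1.3-fold lower number from compound 1 to compound 2 (0.11 log units; within the scatter), is also small.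

Compound 4 `CC(=O)N1N=C(c2ccc3ccccc3c2)OC1c1ccccn1` has pyridin-2-yl in place of 4-fluorophenyl on a saturated ring carbon. The core is unchanged, so the two steps that end at compound 3 are the closest guides, since both change the group at this same carbon. They run from within the scatter to modest. Among the compounds with values here, none of the measured compounds has a hetero atom in the ring at this place, so the data offer no direct precedent for the change and the direction is uncertain.

A step of similar size is expected in this assay, at most a small drift towards a higher number, as the other two compounds both give higher numbers than compound 3. The expected change is small (a 1.8-fold higher number from compound 3 to compound 4 (0.25 log units; within the scatter)). For compound 4 the estimated value is 3.2 ug/mL, with an expected range from 1.4 ug/mL to 7.5 ug/mL.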

Compound 4, half-maximal inhibitory concentration: 5.26 ug/mL
The estimate for compound 4 lay 1.6-fold (0.22 log units) below the measured number; the range from low to high includes it.
By their numbers in this assay, from the lowest: compounds 3, 2, 1 and 4 (each within the scatter of the next, the first and the last beyond it).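

In this assay, pyridin-2-yl on the saturated ring carbon cannot be separated from 2-fluorophenyl (a 1.6-fold higher number from compound 2 to compound 4 (0.19 log units; within the scatter)) or from 2-chlorophenyl (a 1.2-fold higher number from compound 1 to compound 4 (0.09 log units; within the scatter)), but it does stand apart from 4-fluorophenyl (a 2.9-fold higher number from compound 3 to compound 4 (0.46 log units; beyond the scatter)). A six-membered aromatic ring with a hetero atom is therefore compatible with activity at this carbon, at a level that overlaps with the two ring-substituted compounds 1 and 2, but it does not match compound 3, which keeps the lowest number in the set while remaining within the scatter of compound 2. No measured evidence bearing on this result is available.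

From the compounds shown here alone, the step from compound 3 to compound 4 removes the fluorine and brings in the ring nitrogen in a single change, so the share of each remains open, and a plain phenyl at this carbon would separate the two. Also open, going by these compounds, is whether the place of the ring nitrogen matters, as pyridin-4-yl would show, and whether a 4-substituent other than fluorine, such as 4-methoxyphenyl or 4-aminophenyl, holds the number of compound 3.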